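A few compounds are considered here, and "the series" means these few. Any claim that something is new, unique, unknown or untested is made for them only; others in the source may bear on it.

Measured compounds:
compound 1 `COc1ccc(NC(=O)COc2cc(C)nc3ccc(OC)cc23)cc1`, 4.22
compound 2 `COc1ccc2nc(C)cc(OCC(=O)Nc3ccc(Cl)cc3Cl)c2c1`, 6.4
compound 3 `COc1ccc2nc(C)cc(OCC(=O)Nc3ccc(Cl)cc3)c2c1`, 5.15

In a physicochemical assay for lipophilicity, read by HPLC, in phosphate buffer, measured as chromatographic lipophilicity, at pH 7.4 (on this read-out lower numbers stand for lower lipophilicity and higher numbers for higher lipophilicity), compound 3 stands second highest of the three: compound 1 lies a number 0.93 log units higher from compound 1 to compound 3 (beyond the scatter) behind it, while compound 2 lies a number 1.25 log units lower from compound 2 to compound 3 (beyond the scatter) ahead of it. Compound 4 `COc1ccc2nc(C)cc(OCC(=O)NNC(=O)c3ccncc3)c2c1` is not yet measured. It differs from compound 3 in one place: ((pyridin-4-yl)carbonyl)amino in place of 4-chlorophenyl on an amide-type nitrogen. The measured steps all concern a chlorine or a methoxy group on the aromatic ring of the amide substituent, and they were large, as the step of a number 1.25 log units lower from compound 2 to compound 3 (beyond the scatter) and the step of a number 2.18 log units higher from compound 1 to compound 2 (beyond the scatter) show; none of them swaps the whole phenyl ring for a group of the kind entering here, which brings a hydrogen-bond donor and two acceptors as counted above. Since removing a single chlorine already moved this assay by a number 1.25 log units lower from compound 2 to compound 3 (beyond the scatter), a much larger fall is expected for the step of a number 2.55 log units lower from compound 3 to compound 4 (beyond the scatter). Compound 4 is therefore estimated at 2.6, within a range from 1.8 to 3.4.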

Compound 4, distribution coefficient: 1.48
Beside the measured number, compound 4's estimate is 1.12 log units above it; the measured number lies below the stated range.
By their numbers in this assay, from the lowest: compound 4; then compound 1; then compound 3; then compound 2.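

In this assay this amide-type nitrogen carries far more weight than the chlorine and methoxy changes suggested: putting ((pyridin-4-yl)carbonyl)amino in place of 4-chlorophenyl gives a number 3.67 log units lower from compound 3 to compound 4 (beyond the scatter) and exceeds every earlier step. The fall holds whichever phenyl group leaves, with a number 4.92 log units lower from compound 2 to compound 4 (beyond the scatter) for 2,4-dichlorophenyl and a number 2.74 log units lower from compound 1 to compound 4 (beyond the scatter) for 4-methoxyphenyl, so compound 4 ends lowest of the four. Nothing measured here says which part of the entering group accounts for this fall.

On these data alone, what stays open is how much belongs to the pyridine ring and how much to the added carbonyl and amino link. A benzoylamino group, or a pyridin-4-yl ring alone on the amide-type nitrogen, would separate the two.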